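Fluoro to Amino on the Aromatic Carbon

The compounds below may be only part of what the source reports. "The series", "measured", "known", "first", "only" and "open" are said of these compounds alone.

Two compounds share one core. Compound 1 `COc1ccc(/C=C2\Cc3c(cc(OC)c(OC)c3OC)C2=O)cc1O` carries a hydroxy group; compound 2 `COc1ccc(/C=C2\Cc3c(cc(OC)c(OC)c3OC)C2=O)cc1F` carries a fluoro group in its place. In a functional assay on PC-3 cells (Homo sapiens) for antiproliferative activity, read by MTT assay, with a stated time of 48 h (a higher number here means a weaker inhibitor of growth, a lower number a stronger inhibitor of growth), compound 1 gives 213 nM, and compound 2 gives 277 nM. The step of a 1.3-fold higher number from compound 1 to compound 2 (0.11 log units; within the scatter) shows that exchanging hydroxy for fluoro changed little. Among the measured compounds shown here, compound 2 thus holds the higher of the two numbers measured so far, but its only neighbour, compound 1, sits within the scatter of it, so no order between the two can be claimed.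

Compound 3 `COc1ccc(/C=C2\Cc3c(cc(OC)c(OC)c3OC)C2=O)cc1N` differs from compound 2 by amino in place of fluoro on an aromatic carbon. For the measured compounds named here, the single measured step that bears on this exchange is a 1.3-fold higher number from compound 1 to compound 2 (0.11 log units; within the scatter), which replaced one small group on the same aromatic carbon by another and stayed within the scatter. Putting an amino group there is a third small exchange of the same kind, so the expected step of a 1.1-fold lower number from compound 2 to compound 3 (0.04 log units; within the scatter) in this assay is no larger than the scatter and of no settled direction. Compound 3 is therefore expected to give about 250 nM, with a range from 100 nM to 650 nM.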

Compound 3, concentration for 50% growth inhibition: 456 nM
Compound 3: middle estimate off by 1.8-fold (0.26 log units), on the low side; low and high end bracket the measured number.
By their numbers in this assay, from the lowest: compounds 1, 2 and 3 (each within the scatter of the next, the first and the last beyond it).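

In this assay, the step of a 1.6-fold higher number from compound 2 to compound 3 (0.22 log units; within the scatter) stays within the scatter, so amino and fluoro cannot be told apart at this aromatic carbon. Among the compounds shown here, the step of a 2.1-fold higher number from compound 1 to compound 3 (0.33 log units; beyond the scatter) is the first at this position to pass beyond the scatter, though only modestly, so hydroxy and amino can be placed in order here, with the amino compound the weaker inhibitor of growth. Fluoro lies within the scatter of both, which means that the three groups form a shallow slope: only its two ends separate, and the middle compound cannot be firmly ranked against either of them.

No measurement at hand explains the gap between the hydroxy and amino compounds, so it stands as an observation without a cause. As far as these compounds go, it also remains open whether a larger change on this same aromatic carbon, such as a methyl, a chlorine, an acetamide or a longer ether chain, would move the number well beyond this narrow spread, or whether the position tolerates all such groups about equally.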